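This account rests on a few compounds, and the source may have more. Where it says the series, first, only, none or still open, it means among the compounds named here.

Measured so far: compound 1 `CCc1cc(C(C)=O)c(O)cc1OCCCCC#N` with 57%, compound 2 `CCc1cc(C(C)=O)c(O)cc1OCCCCCCC#N` with 73%, and compound 3 `C=CCc1cc(C(C)=O)c(O)cc1OCC#N` with 2%, all in an assay on isolated protein for binding affinity to leukotriene B4 receptor 1 (Homo sapiens), tested at 1 uM; a higher number here means more inhibition at the concentration tested (going by the name of the read-out), a lower number less inhibition.

Compound 1 and compound 2 share one core and differ by 2-cyanoethyl in place of cyano on a saturated chain carbon, four bonds along the chain from an oxygen on an aromatic ring; this change gave a number 16 percentage points higher from compound 1 to compound 2 (beyond the scatter). Compound 3 carries a different core, and the difference between the two cores is not broken down here. The gap in this assay between compound 3 and compound 1 is large, and between compound 3 and compound 2 larger still.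

Compound 4 `C=CCc1cc(C(C)=O)c(O)cc1OCCCC#N` is not yet measured. It differs from compound 3 by 2-cyanoethyl in place of cyano on a saturated chain carbon bound to an oxygen on an aromatic ring. Among the compounds with values here, this is the same kind of change as the one from compound 1 to compound 2, but around the place it differs: there the chain carbon lay four bonds along the chain from the aromatic oxygen, here it is bound directly to that oxygen. Since compound 3 starts from 2% and the earlier change gave a number 16 percentage points higher from compound 1 to compound 2 (beyond the scatter), a modest rise is expected for compound 4, estimated as a number 16 percentage points higher from compound 3 to compound 4 (beyond the scatter). The estimate for compound 4 in this assay is 18%, between 0% and 42%.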

Compound 4, a percentage reported as inhibition, at one concentration (the size of the read-out at that concentration, not a potency): 6%
Compound 4: the middle estimate sits 12 percentage points above what was measured; measured number inside the range.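

In this assay, placing 2-cyanoethyl in place of cyano on a saturated chain carbon bound to an oxygen on an aromatic ring gave a number 4 percentage points higher from compound 3 to compound 4 (within the scatter), so this step on its own shows no effect of the change on the core of compound 3. Set beside the earlier step, it does not show that the change behaves differently on the two cores: the same change on two cores in this assay, a number 16 percentage points higher (beyond the scatter) from compound 1 to compound 2 and a number 4 percentage points higher (within the scatter) from compound 3 to compound 4, 12 percentage points apart, within the scatter of two such steps Nor does it show that the change carries over unchanged, since there are only two steps, they act at different places along the chain, and only the earlier one lies beyond the scatter.

The compounds shown leave open whether a longer chain on the core of compound 3 would approach compound 2 at 73%. They also leave open how a carboxylic acid or an amine at the end of the chain, in place of the nitrile, would read in this assay on either core.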